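This account rests on a few compounds, and the source may have more. Where it says the series, first, only, none or still open, it means among the compounds named here.

Compound 1 `CC(=O)Oc1ccccc1C(=O)O[C@H]1CO[C@H]2[C@@H]1OC[C@H]2OC(=O)c1ccccc1` is tested in an ADME assay on a cell-free system (plasma, Homo sapiens) for metabolic stability, with Plasma (Rattus norvegicus) as the target, read by HPLC, at pH 7.4 (a higher number here means that the compound lasts longer, a lower number that the compound disappears faster), and gives 0.0107 h. Among the three measured compounds it holds the middle number: compound 2 `CC(=O)Oc1ccccc1C(=O)O[C@H]1CO[C@H]2[C@@H]1OC[C@H]2OC(=O)c1cnccc1Cl` gives 0.0322 h, which is a 3.0-fold higher number from compound 1 to compound 2 (0.48 log units; beyond the scatter), and compound 3 `CC(=O)Oc1ccccc1C(=O)O[C@H]1CO[C@H]2[C@@H]1OC[C@H]2O[N+](=O)[O-]` gives 0.00314 h, which is a 3.4-fold lower number from compound 1 to compound 3 (0.53 log units; beyond the scatter); between those two, a 10-fold lower number from compound 2 to compound 3 (1.01 log units; beyond the scatter).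

Compound 4 `CC(=O)Oc1ccccc1C(=O)O[C@H]1CO[C@H]2[C@@H]1OC[C@H]2OC(=O)CCO[N+](=O)[O-]` differs from compound 1 at the ester on the core: 2-(nitrooxy)ethyl in place of phenyl on a carbonyl carbon. Among the compounds with values here, no measured step swaps an aryl group on this carbonyl carbon for a chain, so the nearest guide is the step in which a nitro replaced the benzoyl on the same oxygen, a 3.4-fold lower number from compound 1 to compound 3 (0.53 log units; beyond the scatter), which went down, and the step to compound 2, a 3.0-fold higher number from compound 1 to compound 2 (0.48 log units; beyond the scatter), which went up when a different aromatic ring was kept.

Since compound 4 keeps an ester but loses the aromatic ring and brings in a nitrate, a downward step is expected, estimated as a 1.8-fold lower number from compound 1 to compound 4 (0.25 log units; within the scatter). Compound 4 is therefore expected to give about 0.006 h in this assay, within a range from 0.002 h to 0.02 h.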

Compound 4, half-life: 0.0217 h
Beside the measured number, compound 4's estimate is 3.6-fold (0.56 log units) below it; the whole stated range lies below it.
By their numbers in this assay, from the lowest: compound 3; then compound 1; then compounds 4 and 2 (each within the scatter of the next).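

In this assay, 2-(nitrooxy)ethyl in place of phenyl on the carbonyl carbon gives a 2.0-fold higher number from compound 1 to compound 4 (0.31 log units; beyond the scatter), so at this position a chain with no ring holds up at least as well as the phenyl ring. A nitrate group does not by itself go with the lowest number, as the change from the bare nitro on the oxygen to the (2-(nitrooxy)ethyl)carbonyl group gives a 6.9-fold higher number from compound 3 to compound 4 (0.84 log units; beyond the scatter). The step of a 1.5-fold lower number from compound 2 to compound 4 (0.17 log units; within the scatter) leaves the chain and 4-chloropyridin-3-yl indistinguishable here, so two very different groups on this carbonyl carbon give matching numbers.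

Nothing in the data shown gives a reason for these steps. On these data alone, whether a longer chain, or a carboxylic acid or an amine at the end of the chain in place of the nitrooxy group, would keep the number in this assay remains open.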